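The source may report more compounds than this note shows. Statements on the series, on what has been measured and on what is new or still open speak of the compounds shown alone.

Working notes on the series. Compound 1 `c1cncc(-c2ccccc2OCC2=NCCN2)c1` and compound 2 `c1csc(-c2ccccc2OCC2=NCCN2)c1` share a core and differ only in the aromatic group on an aromatic carbon. In a functional assay with Alpha-1D adrenergic receptor (Homo sapiens) as the target, read by calcium flux (a lower number here means a smaller maximal response, a higher number a larger maximal response), compound 1 gives 38%, and compound 2 gives 93%; the step of a number 55 percentage points higher from compound 1 to compound 2 (beyond the scatter) is the only measured one so far. Compound 2 thus stands highest of the two numbers, with compound 1 beyond the scatter below it. Compound 3 `c1c[nH]c(-c2ccccc2OCC2=NCCN2)c1` is not yet measured. It differs from compound 2 as follows: 1H-pyrrol-2-yl in place of thiophen-2-yl on an aromatic carbon. Among the measured compounds shown here, the one measured step concerns a different exchange, pyridin-3-yl for thiophen-2-yl, so it bears only indirectly on this change; it shows that the group at this aromatic carbon can move the maximal response in this assay by a large amount. A downward step a number 23 percentage points lower from compound 2 to compound 3 (beyond the scatter) is therefore expected, with wide uncertainty. Compound 3 is estimated at 70%, expected between 35% and 100%.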

Compound 3, largest response reached (reported as maximum), in percent of the reference or control that the assay uses: 111%
The estimate for compound 3 lay 41 percentage points below the measured number, and the stated range ends below it.
By their numbers in this assay, from the lowest: compound 1; then compound 2; then compound 3.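

In this assay the exchange of thiophen-2-yl for 1H-pyrrol-2-yl gives a number 18 percentage points higher from compound 2 to compound 3 (beyond the scatter) and shows that the maximal response can still differ between two five-membered aromatic rings with one hetero atom each, so the thiophen-2-yl level is not the top of the range at this aromatic carbon. Measured against pyridin-3-yl, the same group gives a number 73 percentage points higher from compound 1 to compound 3 (beyond the scatter) and widens the spread seen so far at this place, with all three aromatic groups now apart beyond the scatter. Nothing at hand gives a reason for this order.

The compounds shown leave open where furan-2-yl, with oxygen as its hetero atom, would fall in this order. They also leave open whether 1-methylpyrrol-2-yl would keep the response of the 1H-pyrrol-2-yl group.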